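The source may report more compounds than this note shows. Statements on the series, on what has been measured and on what is new or still open speak of the compounds shown alone.

Compound 1, `Cc1ccccc1-c1nn(-c2ccc(F)c(F)c2)cc1CNCCN1CCN(C)CC1`, in an ADME assay on Huh-7 cells (Homo sapiens) for cytotoxicity (a higher number here means that more compound is tolerated, a lower number that less compound is tolerated), gives > 20000 nM, which is a limit of the assay and not a number. Compound 2, `CCN(CC)CCCNCc1cn(-c2ccc(F)cc2F)nc1-c1ccccc1C`, in this assay gives > 20000 nM, again a limit. Compound 3, `CCCN1CCC(CNCc2cn(-c3ccc(C(F)(F)F)cc3)nc2-c2ccc(Cl)cc2)CC1`, in this assay gives 1900 nM.

Within the data shown here, compound 1 thus stands at the limit of > 20000 nM in this assay, at which 2 of the 3 values shown sit; only compound 3, with a different aryl pair and a different amine tail, returns an actual number, and no step between measured compounds is available. Compound 4, `Cc1ccccc1-c1nn(-c2cccc(C(F)(F)F)c2)cc1CNCCN1CCN(C)CC1`, differs from compound 1 in one place: 3-(trifluoromethyl)phenyl in place of 3,4-difluorophenyl on an aromatic nitrogen. Among the measured compounds shown here, no measured pair isolates this change, so its size can only be expected, not read off. The measured values give no ground to expect a step beyond the usual scatter; compound 1 sits at the limit and compound 2, which also differs from compound 1 in its aryl substituents, sits at the same limit, while compound 3 shows that a number below the limit can occur in this series. For compound 4 the expected step is a number no higher from compound 1 to compound 4 (the limit leaves the size open), in either direction within the scatter. Compound 4 is accordingly estimated at 20000 nM in this assay, with a range from 6000 nM to 40000 nM.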

Compound 4, half-maximal cytotoxic concentration: 18000 nM
Compound 4: middle estimate off by 1.1-fold (0.05 log units), on the high side; the measured number falls inside the stated range.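

In this assay, 3-(trifluoromethyl)phenyl in place of 3,4-difluorophenyl on the aromatic nitrogen gives an at least 1.1-fold lower number from compound 1 to compound 4 (0.04 log units; that floor lies within the scatter). With this group at the position, compound 4 returns an actual number, 18000 nM, so the amine tail of compound 1 now has a value that can serve as a reference for further changes at this aryl group. The position takes the larger aryl group, 10 heavy atoms in place of 8, and the floor of the step gives no sign of a change beyond the scatter, although a floor cannot rule one out.

The true size of the step stays open, since compound 1 carries only a limit of the assay, and the same holds for a further compound in the series: the limit of > 20000 nM in this assay, at which 2 of the 4 values shown sit.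

Also open, as far as these compounds go, is whether an unsubstituted phenyl, a 4-chlorophenyl or a 3-cyanophenyl on the aromatic nitrogen would stay at this level, and whether the exchange of aryl groups would read the same with a diethylamino chain in place of the methylpiperazine tail.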